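This account rests on a few compounds, and the source may have more. Where it says the series, first, only, none or still open, it means among the compounds named here.

Compound 1 `C[C@H](Nc1ncnc2[nH]cnc12)c1nn(-c2ccncc2)c2cc(F)ccc12` is the reference point of this small set. In a functional assay on Bel-7402 cells (Homo sapiens) for inhibition, read by sulforhodamine B assay, with a stated time of 72 h, tested at 10 uM (on this read-out higher numbers stand for more inhibition at the one concentration tested (going by the name of the read-out) and lower numbers for less inhibition), compound 1 gives 16%, the highest of the three numbers measured. Compound 2 `CC(C)[C@H](Nc1ncnc2[nH]cnc12)c1nn(-c2cccnc2)c2cc(F)ccc12` gives 5%, a number that lies beyond the scatter below compound 1, and compound 3 `C[C@H](Nc1nc(N)nc2[nH]cnc12)c1nn(-c2cccnc2)c2cc(F)ccc12` gives -5%, further below still. For the measured compounds named here, no single-point step between these measured compounds is available, so the three values are taken as they stand, and compound 1 has the highest number of the three on this read-out.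

Compound 4 `C[C@H](Nc1ncnc2[nH]cnc12)c1nn(-c2cccc(F)c2)c2cc(F)ccc12` has not been measured. It differs from compound 1 in one place: 3-fluorophenyl in place of pyridin-4-yl on an aromatic nitrogen. The group enters on an aromatic nitrogen of a five-membered aromatic ring with two nitrogen, part of a fused system of two rings. Going by the values given here, nothing among the measured compounds shows what this exchange does, so compound 4 is expected to move from compound 1 by a number 1 percentage points lower from compound 1 to compound 4 (within the scatter), a step not expected to exceed the scatter in either direction. On that basis compound 4 is estimated to give 15% in this assay, within a range from -5% to 35%.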

Compound 4, a percentage reported as inhibition, at one concentration (the size of the read-out at that concentration, not a potency): -17%
Beside the measured number, compound 4's estimate is 32 percentage points above it; measured number below the stated range.
By their numbers in this assay, from the lowest: compound 4; then compounds 3 and 2 (each within the scatter of the next); then compound 1.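

For the compounds shown here, on the aromatic nitrogen of the shared core, the exchange of pyridin-4-yl for 3-fluorophenyl gives the first single-place comparison in this set, and in this assay it is a large step, a number 33 percentage points lower from compound 1 to compound 4 (beyond the scatter). This position is therefore not indifferent to the group it carries, since the read-out moves with this one exchange while the rest of compound 1 stays the same. Nothing at hand explains the size of this step.

From the compounds shown here alone, whether the step follows the loss of the ring nitrogen or the entry of the fluorine stays open, and an unsubstituted phenyl on this nitrogen would separate the two. Also open, going by these compounds, is how a ring carrying an amine or a methoxy group would read at this position.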